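Replacing the Anilino Group of Compound 2

This account rests on a few compounds, and the source may have more. Where it says the series, first, only, none or still open, it means among the compounds named here.

Compound 2 `Cn1ccc2cc(-c3ccc4oc(Nc5ccccc5)nc4c3)ccc21` gives 48 nM in an assay on HEK293 cells for inhibition of Fatty-acid amide hydrolase 1 (Homo sapiens), read by fluorescence; a higher number here means a weaker inhibitor, a lower number a stronger inhibitor. Compound 1 `Cn1ncc2cc(-c3ccc4oc(NC5CCCCC5)nc4c3)ccc21` gives 61 nM in this assay, and the two numbers lie within the usual scatter of each other, so they cannot be told apart. Compound 3 `Cn1ccc2cc(-c3ccc4oc(N5CCn6cccc6C5)nc4c3)ccc21` differs from compound 2 in a single place: a group of 9 heavy atoms (7 carbon, 2 nitrogen; one five-membered aromatic ring with 1 hetero atom, one six-membered non-aromatic ring with 2 hetero atoms) in place of a group of 7 heavy atoms (6 carbon, 1 nitrogen; one six-membered aromatic ring of carbon only), on an aromatic carbon. Among the measured compounds shown here, no measured pair shows a change of this kind, so the expectation rests on the structures alone: a modest step toward a higher number, at the edge of the scatter, is expected, a 2.5-fold higher number from compound 2 to compound 3 (0.40 log units; beyond the scatter). Compound 3 is estimated at 120 nM, with a range from 30 nM to 500 nM.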

Compound 3, half-maximal inhibitory concentration: 42 nM
Compound 3: the middle estimate sits 2.9-fold (0.46 log units) above what was measured, and the stated range covers the measured number.
By their numbers in this assay, from the lowest: compounds 3, 2 and 1 (each within the scatter of the next).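

On the aromatic carbon of the five-membered aromatic ring with 1 nitrogen and 1 oxygen, swapping the anilino group for this two-ring group with 9 heavy atoms gives a 1.1-fold lower number from compound 2 to compound 3 (0.06 log units; within the scatter) in this assay and so leaves compound 2 and compound 3 indistinguishable. The single hydrogen-bond donor of the anilino group can therefore go, in this pair, without a change that can be read. Nothing measured here explains this result.

Still open, as far as these compounds go, is whether a simple piperidine or morpholine in the same place would give a similar number. Either group would lack the five-membered aromatic ring, so it would show whether that ring matters.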